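One side chain swapped in a cytotoxicity test

The source may report more compounds than this note shows. Statements on the series, on what has been measured and on what is new or still open speak of the compounds shown alone.

- compound 1 (`CCn1c(C(=O)NCCN(C)C)ccc1C(CC)(CC)c1ccc(OCC(=O)C(C)(C)C)c(C)c1`) gives 2500 nM
- compound 2 (`CCn1c(C(=O)NCCCN(C)C)ccc1C(CC)(CC)c1ccc(OCC(O)C(C)(C)C)c(C)c1`) gives 470 nM

In an ADME assay on L02 cells (Homo sapiens) for cytotoxicity, read by MTT assay, with a stated time of 48 h (on this read-out higher numbers stand for weaker inhibition and lower numbers for stronger inhibition), compound 2 holds the lower number of the two, and its gap to compound 1 lies beyond the usual scatter. Compound 3 (`C#CC(C)OC(=O)c1ccc(C(CC)(CC)c2ccc(OCC(O)C(C)(C)C)c(C)c2)n1CC`) carries (1-methylprop-2-yn-1-yl)oxy in place of (3-(dimethylamino)propyl)amino on a carbonyl carbon. Among the compounds with values here, no measured pair shows this kind of change, so any forecast here is loose. The expected move is an 11-fold higher number from compound 2 to compound 3 (1.03 log units; beyond the scatter) toward a higher number, meaning weaker inhibition, and it is expected to lie beyond the scatter. The estimate for compound 3 is 5000 nM (expected range 1000 nM to 30000 nM).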

Compound 3, half-maximal inhibitory concentration: 23700 nM
For compound 3 the middle estimate is 4.7-fold (0.68 log units) below the measured one; low and high end bracket the measured number.
By their numbers in this assay, from the lowest: compound 2; then compound 1; then compound 3.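

In this assay the group on this carbonyl carbon proves able to shift the result strongly: replacing (3-(dimethylamino)propyl)amino with (1-methylprop-2-yn-1-yl)oxy gives a 50-fold higher number from compound 2 to compound 3 (1.70 log units; beyond the scatter) and so much weaker inhibition. This is the first change in a single place among these compounds, and it shows that this site is sensitive to the group it carries. Nothing available explains the shift.

Going by these compounds, it remains open whether the change comes from losing the dimethylamino group, the amide hydrogen or the triple bond. A carboxylic acid or a plain methyl ester on this carbonyl carbon would help separate these possibilities.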